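From 2-methylphenyl to 2-methoxyphenyl on a shared core

The source may report more compounds than this note shows. Statements on the series, on what has been measured and on what is new or still open speak of the compounds shown alone.

Of the compounds shown here, three with one shared core have been measured. In a physicochemical assay for pharmacokinetics (on this read-out lower numbers stand for a shorter-lived compound and higher numbers for a longer-lived compound), compound 1 `COc1ccc(CNC(=O)N2C(=O)c3ccccc3S2(=O)=O)cc1` gives 0.187 h, compound 2 `O=C(NCc1ccccc1Cl)N1C(=O)c2ccccc2S1(=O)=O` gives 0.42 h and compound 3 `Cc1ccccc1CNC(=O)N1C(=O)c2ccccc2S1(=O)=O` gives 0.792 h. The set shows a 4.2-fold higher number from compound 1 to compound 3 (0.63 log units; beyond the scatter), so compound 3 stands clear of the 4-methoxyphenyl compound. The set also shows a 1.9-fold higher number from compound 2 to compound 3 (0.28 log units; within the scatter), so compound 3 cannot be told apart from the 2-chlorophenyl compound.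

The next compound is compound 4 `COc1ccccc1CNC(=O)N1C(=O)c2ccccc2S1(=O)=O`, which carries methoxy in place of methyl on an aromatic carbon, (methoxy in place of methyl on an aromatic carbon). For the measured compounds named here, no measured step makes this exact change, so the evidence is indirect. The swap of chloro for methyl is the nearest one, and it stayed inside the scatter, as the step given above for compound 3 shows. Going by the values given here, the only methoxy compound measured, compound 1, carries its group as 4-methoxyphenyl and lies lowest, with a 2.2-fold higher number from compound 1 to compound 2 (0.35 log units; beyond the scatter) as the other step from it. Compound 4 shares its methoxy with compound 1 and its 2-substituted pattern with the other two, so a drop is expected in this assay, but only a modest one. The expected step is a 2.1-fold lower number from compound 3 to compound 4 (0.32 log units; beyond the scatter). For compound 4 the estimated half-life is 0.38 h, with an expected range from 0.18 h to 0.8 h.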

Compound 4, half-life: 1.12 h
Compound 4: the middle estimate sits 2.9-fold (0.47 log units) below what was measured; measured number above the stated range.
By their numbers in this assay, from the lowest: compound 1; then compounds 2, 3 and 4 (each within the scatter of the next, the first and the last beyond it).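

In this assay the change gives a 1.4-fold higher number from compound 3 to compound 4 (0.15 log units; within the scatter) and so cannot be told apart from no change, which means that methoxy and methyl on this aromatic carbon, ortho to a large group, give the same result within the scatter. Chloro at this place behaves differently, since methoxy in its place gives a 2.7-fold higher number from compound 2 to compound 4 (0.43 log units; beyond the scatter) and so stands clear of it, even though compound 2 and compound 3 could not be told apart from each other. The same methoxy group also gives very different results depending on where it sits, with 2-methoxyphenyl in place of 4-methoxyphenyl giving a 6.0-fold higher number from compound 1 to compound 4 (0.78 log units; beyond the scatter) and showing that the low number of compound 1 goes with the 4-methoxyphenyl pattern and not with methoxy as such.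

Nothing in the data shown bears on what lies behind these steps. From the compounds shown here alone, it remains open whether an ethoxy group, a longer chain or an amine on this aromatic carbon would stay level with methyl and methoxy, and whether 4-methylphenyl or 4-chlorophenyl would fall as low as 4-methoxyphenyl.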